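The compounds below may be only part of what the source reports. "The series", "measured", "known", "first", "only" and "open" are said of these compounds alone.

Measured compounds: compound 1 `COc1ccc(C2N=C(SCc3ccccc3)NC(C)=C2C(=O)Nc2ccc(Br)cc2)cc1` with 5.6%; compound 2 `COc1ccc(C2N=C(SCc3ccc(Cl)cc3)NC(C)=C2C(=O)Nc2ccc(Br)cc2)cc1` with 20%; compound 3 `CC1=C(C(=O)Nc2ccc([N+](=O)[O-])cc2)C(c2ccc(Br)cc2)N=C(SCc2ccccc2)N1` with 19.5%.

In a functional assay on the whole organism (artery, strain albino) with Rattus norvegicus as the target, with a stated time of 900 min, at a dose of 10 mg/kg by the oral route (on this read-out higher numbers stand for more inhibition at the one dose given (going by the name of the read-out) and lower numbers for less inhibition), compound 1 gives 5.6% and compound 2 gives 20%. The change between them is chloro in place of hydrogen on an aromatic carbon, and it made a step of a number 14.4 percentage points higher from compound 1 to compound 2 (beyond the scatter). Compound 3 gives 19.5% in this assay; how the core of compound 3 differs from the core of compound 1 is not broken down here. Compound 4 `CC1=C(C(=O)Nc2ccc([N+](=O)[O-])cc2)C(c2ccc(Br)cc2)N=C(SCc2ccccc2Cl)N1` has not been measured. It differs from compound 3 by chloro in place of hydrogen on an aromatic carbon, the same kind of change as from compound 1 to compound 2, though the place is not the same: in compound 2 the chloro sits para to a large group, whereas in compound 4 it sits ortho to a large group. Going by the values given here, because the earlier step was a number 14.4 percentage points higher from compound 1 to compound 2 (beyond the scatter), a rise of similar size is expected, but with wide uncertainty since the place differs and only one pair shows the change. The step from compound 3 to compound 4 is estimated at a number 8.5 percentage points higher from compound 3 to compound 4 (within the scatter). Compound 4 is expected to give about 28%, between 12% and 45%.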

Compound 4, a percentage reported as inhibition, in the whole organism at one dose (the size of the read-out at that dose, not a potency): 4.1%
The estimate for compound 4 lay 23.9 percentage points above the measured number; measured number below the stated range.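

In this assay, chloro in place of hydrogen on an aromatic carbon gave a number 15.4 percentage points lower from compound 3 to compound 4 (beyond the scatter), so the change did not keep its direction when it moved from one core to the other: the same change on two cores in this assay, a number 14.4 percentage points higher (beyond the scatter) from compound 1 to compound 2 and a number 15.4 percentage points lower (beyond the scatter) from compound 3 to compound 4, 29.8 percentage points apart, beyond the scatter of two such steps

On these two pairs, then, the earlier step cannot be carried over as a fixed gain in this series. The pairs do not show what lies behind the reversal, for the core and the place of the chloro differ together: in compound 4 it sits ortho to a large group, which is not its place in compound 2, and two pairs cannot separate these two differences.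

The compounds shown leave open how the core of compound 3 responds to chloro in the place it holds in compound 2, and whether a 2-chlorobenzyl group would also lower the number on the core of compound 1. They also leave open how that aromatic ring would read with a nitrile, a carboxylic acid or an amine in place of the chloro.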